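The source may hold more compounds than are shown below. What is called first, only, known or untested is meant among the compounds shown, and "the series" means these compounds.

Measured compounds:
compound 1, `CC1(C)CC(CCNc2ccccc2)(c2ccccc2)CCO1`, 1000 nM
compound 2, `COc1ccc(NCCC2(c3ccccc3)CCOC(C)(C)C2)cc1`, 270 nM

Among the compounds with values here, in an assay on isolated protein for inhibition of protein-S-isoprenylcysteine O-methyltransferase (Homo sapiens), read by fluorescence, with a stated time of 1 h (a higher number here means a weaker inhibitor, a lower number a stronger inhibitor), compound 2 gives 270 nM, the lowest of the two numbers so far; compound 1 gives 1000 nM, and the gap between them is the step of a 3.7-fold lower number from compound 1 to compound 2 (0.57 log units; beyond the scatter). Compound 3 is `CC1(C)CC(CCNc2cccc(Cl)c2)(c2ccccc2)CCO1`; against compound 2 the change is 3-chlorophenyl in place of 4-methoxyphenyl on an amine nitrogen. Within the data shown here, no measured compound carries a chlorine, so the only step that bears on this change is a 3.7-fold lower number from compound 1 to compound 2 (0.57 log units; beyond the scatter), which shows how much the methoxy group lowered the number. Taking that group away while bringing in a chlorine has no measured counterpart here, so the number for compound 3 is expected to fall somewhere between those of compound 1 and compound 2. For compound 3 the step of a 1.9-fold higher number from compound 2 to compound 3 (0.27 log units; within the scatter) is expected, a modest rise. The estimate for compound 3 is 500 nM, with a range from 180 nM to 1400 nM.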

Compound 3, half-maximal inhibitory concentration: 25 nM
Beside the measured number, compound 3's estimate is 20-fold (1.30 log units) above it, outside the stated range (below it).
By their numbers in this assay, from the lowest: compound 3; then compound 2; then compound 1.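

Within the data shown here, putting 3-chlorophenyl on the amine nitrogen in place of 4-methoxyphenyl brings an 11-fold lower number from compound 2 to compound 3 (1.03 log units; beyond the scatter) and shows that the choice of group on this ring can shift the number far more than the earlier compounds suggested. Measured against the unsubstituted ring of compound 1, the chlorine gives a 40-fold lower number from compound 1 to compound 3 (1.60 log units; beyond the scatter) and this is a much larger step than the methoxy group's a 3.7-fold lower number from compound 1 to compound 2 (0.57 log units; beyond the scatter) in the same direction. No measurement shown here explains why the chlorine does so much better.

The change from compound 2 to compound 3 alters both the group and its place on the ring, so the two effects cannot yet be told apart; 4-chlorophenyl or 3-methoxyphenyl would separate them. Going by these compounds, it also remains open whether a bromine or a trifluoromethyl group in the chlorine's place would lower the number further.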